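The source may report more compounds than this note shows. Statements on the series, on what has been measured and on what is new or still open speak of the compounds shown alone.

Three compounds have been measured in a functional assay on HEK293 cells for antagonist activity at transient receptor potential cation channel subfamily V member 1 (Rattus norvegicus), read by calcium flux; on this read-out lower numbers stand for stronger inhibition and higher numbers for weaker inhibition:

compound 1, `FC(F)(F)c1ccc(Nc2ncnc3c2CCN(c2ncccc2C(F)(F)F)C3)cc1`, gives 71 nM
compound 2, `FC(F)(F)c1ccc(Nc2cccc3sc(Nc4c(Cl)cccc4Cl)nc23)cc1`, gives > 5000 nM
compound 3, `Cc1cccc(C)c1Nc1nc2c(Nc3ccc(C(F)(F)F)cc3)ncnc2s1`, gives 6 nM

The value given for compound 2 is a limit of the assay and not a number (the limit of > 5000 nM in this assay, at which 1 of the 3 values shown sits). Among the two numbers, compound 3 stands lowest, and compound 1 sits at a higher number, a gap that lies beyond the usual scatter. Compound 3 and compound 1 share neither core nor the second aryl group, so no single change is read from that pair.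

Compound 4, `FC(F)(F)c1ccc(Nc2ncnc3sc(Nc4ccccc4C(F)(F)F)nc23)cc1`, has not yet been measured. It differs from compound 3 in one place: 2-(trifluoromethyl)phenyl in place of 2,6-dimethylphenyl on a nitrogen on an aromatic ring. No pair among the measured compounds differs only there, so the size of this step is not known from the numbers shown. Compound 2 carries a dichlorophenyl on a nitrogen and sits at the limit, but its core differs from that of compound 3, so it gives no direct reading of the change.

Compound 4 is expected to give 20 nM in this assay, with a range from 5 nM to 100 nM. The step of a 3.3-fold higher number from compound 3 to compound 4 (0.52 log units; beyond the scatter) is estimated as a modest rise, only a little beyond the scatter.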

Compound 4, half-maximal inhibitory concentration: 37 nM
Estimate against measurement, compound 4: 1.9-fold (0.27 log units) below; the range from low to high includes it.
By their numbers in this assay, from the lowest: compound 3; then compounds 4 and 1 (each within the scatter of the next). At a limit, above all of these: compound 2.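

Going by these compounds alone, the pair formed by compound 3 and compound 4 is the first in the set that differs in one place, and it puts a size on a change at this position. In this assay, replacing 2,6-dimethylphenyl with 2-(trifluoromethyl)phenyl on a nitrogen on an aromatic ring, with the rest of the molecule unchanged, gives a modest loss of inhibition (a 6.2-fold higher number from compound 3 to compound 4 (0.79 log units; beyond the scatter)), and compound 4 still gives a measured number of 37 nM rather than a limit, so this position accepts both groups while the 2,6-dimethylphenyl of compound 3 gives the lower number. Nothing measured here explains this step.

The single step changes two things at once, since one group has two methyl groups and the other has one trifluoromethyl, so the compounds shown cannot separate the loss of the second substituent from the exchange of methyl for trifluoromethyl. Going by these compounds, a 2-methylphenyl or an unsubstituted phenyl on the same nitrogen would divide the step, and whether a 2,6-dichlorophenyl behaves like the 2,6-dimethylphenyl on this core also stays open.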